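Methyl for hydrogen at two places in an aldosterone synthase series

A few compounds are considered here, and "the series" means these few. Any claim that something is new, unique, unknown or untested is made for them only; others in the source may bear on it.

Measured compounds:
compound 1 `CCC1c2cc(Cl)ccc2C(=O)N1c1cccnc1` gives 3340 nM
compound 2 `CC1c2cc(Cl)ccc2C(=O)N1c1cccnc1` gives 1250 nM
compound 3 `CC(=O)N[C@@H]1CCCc2c1cncc2N1Cc2cc(Cl)ccc2C1=O` gives 2330 nM

In an ADME assay on cells for inhibition of cytochrome P450 11B1, mitochondrial (Homo sapiens), read by HTRF (on this read-out higher numbers stand for weaker inhibition and lower numbers for stronger inhibition), compound 2 gives 1250 nM, and compound 1 gives 3340 nM. The two differ by methyl in place of hydrogen on a saturated chain carbon bound to a saturated ring carbon, and that change produced a 2.7-fold higher number from compound 2 to compound 1 (0.43 log units; beyond the scatter). Compound 3, which gives 2330 nM, sits on a different core; the difference between the two cores is not broken down here.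

Compound 4 `CCC(=O)N[C@@H]1CCCc2c1cncc2N1Cc2cc(Cl)ccc2C1=O` has not yet been tested. It differs from compound 3 by methyl in place of hydrogen on a saturated chain carbon bound to a carbonyl carbon. This is the same kind of change as that from compound 2 to compound 1, but the place is not the same: there the added methyl sits on a saturated chain carbon bound to a saturated ring carbon, here on a saturated chain carbon bound to a carbonyl carbon. Resting on the step of a 2.7-fold higher number from compound 2 to compound 1 (0.43 log units; beyond the scatter) as the only example of this kind of change, compound 4 is expected to show a 1.7-fold higher number from compound 3 to compound 4 (0.23 log units; within the scatter), with wide uncertainty since the place differs. Compound 4 is therefore estimated at 4000 nM, between 1500 nM and 10000 nM.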

Compound 4, half-maximal inhibitory concentration: 5210 nM
Beside the measured number, compound 4's estimate is 1.3-fold (0.11 log units) below it; the measured number falls inside the stated range.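

In this assay, methyl in place of hydrogen on a saturated chain carbon bound to a carbonyl carbon, which turns the acetamido group into a propanoylamino group, gave a 2.2-fold higher number from compound 3 to compound 4 (0.35 log units; beyond the scatter). Set beside the earlier step, the same kind of change raised the number on both cores, and the two steps cannot be told apart in size: the same change on two cores in this assay, a 2.7-fold higher number (0.43 log units; beyond the scatter) from compound 2 to compound 1 and a 2.2-fold higher number (0.35 log units; beyond the scatter) from compound 3 to compound 4, 1.2-fold (0.08 log units) apart, within the scatter of two such steps. Among these compounds, this shows that, in this read-out, the change carried over from one core to the other in direction and in size, but it rests on only two pairs, with the methyl at a different place in each, and it shows neither why the steps agree nor that they would agree on any further core.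

The compounds shown leave open whether a longer chain, such as butanoyl, would raise the number further on the core of compound 3. They also leave open what an amine or a carboxylic acid at the end of that chain would do.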